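The source may hold more compounds than are shown below. What is called first, only, known or untested is meant among the compounds shown, and "the series" means these compounds.

Measured so far:
Compound 1 `c1ccc(COC[C@H]2O[C@@H]3C[C@@H]3[C@@H](OCc3ccccc3)[C@@H]2OCc2ccccc2)cc1`: 38500 nM
Compound 2 `CCC[C@H]1O[C@H](COCc2ccccc2)[C@H](OCc2ccccc2)[C@H](OCc2ccccc2)[C@H]1O`: "not active" (no number reported)

The read-out is a functional assay on HL-60 cells (Homo sapiens) for antiproliferative activity, read by MTT assay; on this read-out higher numbers stand for weaker inhibition and lower numbers for stronger inhibition. Going by the values given here, there, compound 1 gives 38500 nM, the only number available, while compound 2 is reported as "not active" (no number reported) and so offers no numerical comparison.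

Compound 3 `c1ccc(COC[C@H]2O[C@H]3C[C@H]3[C@@H](OCc3ccccc3)[C@@H]2OCc2ccccc2)cc1`, still unmeasured, shares its atoms and bonds with compound 1: the two compounds have the same atoms and bonds and differ only in configuration as drawn: 2 of 5 stereo elements differ; a stereocentre at a saturated ring carbon is drawn R in compound 1 and S in compound 3; a stereocentre at a saturated ring carbon is drawn S in compound 1 and R in compound 3. Two stereocentres at saturated ring carbons differ, one drawn R in compound 1 and S in compound 3, the other drawn S in compound 1 and R in compound 3.

Among the compounds with values here, no measured pair shows how such a configurational change plays out in this assay. The expectation therefore rests on compound 1 at 38500 nM, and no step beyond the scatter is expected in either direction, though a report without a number remains possible. The expected change is a 1.0-fold higher number from compound 1 to compound 3 (0.02 log units; within the scatter). For compound 3 the estimated value is 40000 nM, with an expected range from 15000 nM to 100000 nM.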

Compound 3, half-maximal inhibitory concentration: "not active" (no number reported)
No number was reported for compound 3; the estimate stays without a comparison.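

In this assay compound 3 is reported as not active without a number, and no step can be read from compound 1, which gives 38500 nM. The compounds shown leave open how large a shift in this assay goes with what separates this pair: the fact that compounds 1 and 3 differ only in the configuration as drawn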